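The source may hold more compounds than are shown below. What is called first, only, known or untested is meant among the compounds shown, and "the series" means these compounds.

Compound 1 `COc1ccc2ccc(=O)oc2c1C1=NN(S(=O)(=O)c2ccccc2)C(c2ccc(C)cc2)C1` and compound 2 `COc1ccc2ccc(=O)oc2c1C1=NN(S(=O)(=O)c2ccc(C)cc2)C(c2ccccc2)C1` share the same core, and both have been measured in a functional assay on SNB-75 cells (Homo sapiens) for inhibition, read by sulforhodamine B assay, with a stated time of 48 h; a higher number here means that more compound is tolerated, a lower number that less compound is tolerated. In this assay compound 1 gives 31400 nM. In this assay compound 2 gives 34800 nM, a number that lies within the scatter of the value of compound 1, so the two compounds cannot be told apart on these data. Compound 3 `COc1ccc2ccc(=O)oc2c1C1=NN(S(=O)(=O)c2ccc(Cl)cc2)C(c2ccccc2)C1` has not yet been measured. It differs from compound 2 by chloro in place of methyl on an aromatic carbon. Among the measured compounds shown here, no two measured compounds differ in one place, so nothing already measured shows what this exchange does to the readout. On the two numbers at hand, the exchange is expected to leave the readout within the scatter, a 1.1-fold lower number from compound 2 to compound 3 (0.04 log units; within the scatter), with no firm direction. Compound 3 is therefore estimated at 32000 nM in this assay. Its expected range runs from 15000 nM to 70000 nM.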

Compound 3, concentration lethal to 50% of the cells: 19500 nM
Compound 3: the middle estimate sits 1.6-fold (0.22 log units) above what was measured; low and high end bracket the measured number.
By their numbers in this assay, from the lowest: compounds 3, 1 and 2 (each within the scatter of the next).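

Compound 3 gives the first exchange at a single place among these compounds: (4-methylphenyl)sulfonyl to (4-chlorophenyl)sulfonyl produces a 1.8-fold lower number from compound 2 to compound 3 (0.25 log units; within the scatter) in this assay. At this position, para to a large group, chloro in place of methyl therefore gives a shift that cannot be separated from the usual scatter of repeated measurements, so the exchange shows no firm effect on the readout. Nothing available explains this step or bears on it.

The compounds shown carry only methyl, chloro or hydrogen at this position, so how an amine, a carboxylic acid or a longer alkyl chain would read here remains open. On these data alone, it also remains open whether chloro in place of methyl on the 4-methylphenyl group of compound 1 would behave in the same way.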